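Amide to urea: does a second amide-type nitrogen help?

The compounds below may be only part of what the source reports. "The series", "measured", "known", "first", "only" and "open" are said of these compounds alone.

Measured so far: compound 1 `COc1cc(-c2nn(-c3cccc(NC(=O)Nc4cc(C(F)(F)F)cc(C(F)(F)F)c4)c3)cc2-c2ccncc2)ccc1Cl` gives > 50000 nM; compound 2 `COc1cc(-c2nn(-c3cccc(NC(=O)c4cccc(C(F)(F)F)c4)c3)cc2-c2ccncc2)ccc1Cl` gives 26600 nM; compound 3 `O=C(Nc1cccc(-n2cc(-c3ccncc3)c(-c3ccc(Cl)c(O)c3)n2)c1)Nc1ccc(Cl)c(Cl)c1` gives > 32500 nM.

These three compounds share one core and were tested in a functional assay on RPMI-8226 cells (Homo sapiens) for inhibition, read by sulforhodamine B assay, with a stated time of 48 h; a higher number here means a weaker inhibitor of growth, a lower number a stronger inhibitor of growth. Compound 2 is the only one of the three that returns an actual number, at 26600 nM. For compound 1 the result is a limit of the assay, > 50000 nM, not a number (the limit of > 50000 nM in this assay, at which 1 of the 3 values shown sits). For compound 3 the result is likewise a limit, > 32500 nM (the limit of > 32500 nM in this assay, at which 1 of the 3 values shown sits). So compound 2 stands as the one measured point, and the other two sit at limits that tell only that growth inhibition was not reached within the tested range.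

Compound 4 `COc1cc(-c2nn(-c3cccc(NC(=O)Nc4cccc(C(F)(F)F)c4)c3)cc2-c2ccncc2)ccc1Cl` has not been measured. It differs from compound 2 in one place: (3-(trifluoromethyl)phenyl)amino in place of 3-(trifluoromethyl)phenyl on a carbonyl carbon. Among the measured compounds shown here, no step between measured compounds covers this change, so the expectation rests on compound 2 alone and on the limits seen for compound 1 and compound 3. The step from compound 2 to compound 4 is expected to be small, within the scatter or slightly weaker, giving a 1.1-fold higher number from compound 2 to compound 4 (0.02 log units; within the scatter). Compound 4 is therefore estimated at 28000 nM, with a range from 7000 nM to 60000 nM.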

Compound 4, concentration for total growth inhibition: 3120 nM
Beside the measured number, compound 4's estimate is 9.0-fold (0.95 log units) above it; measured number outside the range, below it.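

In this assay, among the compounds shown here, (3-(trifluoromethyl)phenyl)amino in place of 3-(trifluoromethyl)phenyl on a carbonyl carbon gives an 8.5-fold lower number from compound 2 to compound 4 (0.93 log units; beyond the scatter), which turns the amide into a urea and provides the first comparison here in which this one change can be read on its own. The urea alone does not settle the outcome, as the other substituents on the aromatic ring also count: hydrogen in place of trifluoromethyl on an aromatic carbon gives an at least 16-fold lower number from compound 1 to compound 4 (1.20 log units; beyond the scatter). That second step starts from a limit and not a number, so its true size remains unknown: the limit of > 50000 nM in this assay, at which 1 of the 4 values shown sits.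

The compounds shown do not separate the effect of the added nitrogen from that of its hydrogen, a question that a urea with a methyl group on that nitrogen, or a carbamate with an oxygen in its place, would address. They also leave open whether the gain in compound 4 would survive with a nitrile in place of its trifluoromethyl, or with a cyclohexyl group in place of its aromatic ring.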